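Putting a benzyl group back on the nitrogen

The compounds below may be only part of what the source reports. "The series", "measured", "known", "first", "only" and "open" are said of these compounds alone.

Measured so far in an ADME assay on CHO cells (Cricetulus griseus) for inhibition, read by MTT assay (a higher number here means a weaker inhibitor, a lower number a stronger inhibitor), are three compounds:
Compound 1 `CCN(CC)Cc1cc(Nc2nc3ccccc3n2Cc2ccc(C(F)(F)F)cc2)ccc1O` gives 17500 nM
Compound 2 `CCN(CC)Cc1cc(Nc2nc3ccccc3[nH]2)ccc1O` gives > 50000 nM (a limit of the assay, not a number)
Compound 3 `CC(C)(C)NCc1cc(C(C)(C)C)cc(Nc2nc3ccccc3[nH]2)c1O` gives 30500 nM

Compound 2 has only a limit: it stands at the limit of > 50000 nM in this assay, at which 1 of the 3 values shown sits, and no exact value is known. The change 4-fluorobenzyl in place of hydrogen on an aromatic nitrogen is 4-fluorobenzyl in place of hydrogen on an aromatic nitrogen, and its product, compound 4 `CCN(CC)Cc1cc(Nc2nc3ccccc3n2Cc2ccc(F)cc2)ccc1O`, has not yet been measured.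

Within the data shown here, one measured step bears on this change, running the opposite way. Hydrogen in place of 4-(trifluoromethyl)benzyl on an aromatic nitrogen gave an at least 2.8-fold higher number from compound 1 to compound 2 (0.45 log units; beyond the scatter) and that lies beyond the scatter, with its true size left open by the limit. Among the measured compounds shown here, no single-place step links compound 3 to the others, so it adds nothing here.

Adding a benzyl group back is therefore expected to lower the number, which would mean a stronger inhibitor, although the swap between the two benzyl groups has no measurement of its own. Compound 4 is expected to land near compound 1, at 17500 nM in this assay as the closest guide. The estimate in numbers is an at least 2.2-fold lower number from compound 2 to compound 4 (0.35 log units; beyond the scatter) and it rests on that one comparison. The estimate for compound 4 is 22000 nM as the expected value, with 10000 nM to 48000 nM as its range.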

Compound 4, half-maximal inhibitory concentration: 12000 nM
For compound 4 the middle estimate is 1.8-fold (0.26 log units) above the measured one; the range from low to high includes it.
By their numbers in this assay, from the lowest: compounds 4, 1 and 3 (each within the scatter of the next, the first and the last beyond it). At a limit, above all of these: compound 2.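

Compound 4 gives this aromatic nitrogen a second benzyl example in this assay. Placing 4-fluorobenzyl there in place of hydrogen gave a step beyond the scatter (an at least 4.1-fold lower number from compound 2 to compound 4 (0.61 log units; beyond the scatter)), so the lower number seen with compound 1 is not tied to 4-(trifluoromethyl)benzyl alone. Exchanging the substituent on the benzyl ring made no change that can be told from the scatter (a 1.5-fold lower number from compound 1 to compound 4 (0.16 log units; within the scatter)), so the two benzyl groups cannot be separated in this assay, and the hydrogen-to-benzyl change is what matters among the compounds shown. From the compounds shown here alone, compound 2 has a limit and not a number, so the full size of that change stays open: the limit of > 50000 nM in this assay, at which 1 of the 4 values shown sits.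

The compounds shown leave open whether the ring of the benzyl group is needed at all, which a methyl group or a longer alkyl chain on the same nitrogen would help to answer, and whether an amine or a carboxylic acid on the benzyl ring would still fit the same trend. They also leave open whether 4-fluorobenzyl on this nitrogen would lower the number in the same way on the core of compound 3.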